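The source may report more compounds than this note shows. Statements on the series, on what has been measured and on what is new or still open speak of the compounds shown alone.

Three compounds have been measured in a functional assay for inhibition, tested at 40 ug/mL; on this read-out higher numbers stand for a stronger effect at the one concentration tested and lower numbers for a weaker effect:
compound 1 `Cc1cc(O)c(C(C)C)cc1-c1cc(-c2ccccc2[N+](=O)[O-])c(C#N)c(=O)[nH]1` gives 25.5%
compound 2 `COc1cc(OC)c(-c2cc(-c3cc(C(C)C)c(O)cc3C)[nH]c(=O)c2C#N)c(OC)c1` gives 52.6%
compound 3 `Cc1cc(O)c(C(C)C)cc1-c1cc(-c2ccccc2Cl)c(C#N)c(=O)[nH]1` gives 20%

Compound 3 has the lowest of the three numbers; its nearest neighbour is compound 1, whose value lies within the scatter of it, while compound 2 lies beyond the scatter above it. Compound 4 `Cc1cc(O)c(C(C)C)cc1-c1cc(-c2cccs2)c(C#N)c(=O)[nH]1` changes compound 3 in one place: thiophen-2-yl in place of 2-chlorophenyl on an aromatic carbon. For the measured compounds named here, only one measured step bears on this position, a number 5.5 percentage points lower from compound 1 to compound 3 (within the scatter), and it exchanged a single group on that ring rather than the ring itself. Going by the values given here, no measured step exchanges the whole ring, so no direction is indicated and no move beyond the scatter is expected. The expected step is a number 5 percentage points higher from compound 3 to compound 4 (within the scatter). The estimate for compound 4 is 25%, with a range from 8% to 48%.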

Compound 4, a percentage reported as inhibition, at one concentration (the size of the read-out at that concentration, not a potency): 41%
For compound 4 the middle estimate is 16 percentage points below the measured one, and the stated range covers the measured number.
By their numbers in this assay, from the lowest: compounds 3 and 1 (each within the scatter of the next); then compound 4; then compound 2.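

In this assay, exchanging the whole ring at this position gives a number 21 percentage points higher from compound 3 to compound 4 (beyond the scatter) and a number 15.5 percentage points higher from compound 1 to compound 4 (beyond the scatter). The earlier swap of a single group on the ring stayed within the scatter, so this position responds more clearly when thiophen-2-yl replaces the ring itself. No supporting measurement accounts for this rise.

Still open, as far as these compounds go, is whether the sulfur or the smaller ring goes with the higher number. A furan-2-yl ring, with oxygen in place of sulfur, and a plain phenyl ring would help separate those two features.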